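Removing one methyl from the pyrazole

The compounds below may be only part of what the source reports. "The series", "measured", "known", "first", "only" and "open" are said of these compounds alone.

Values in a functional assay on CWR22R cells (Homo sapiens) for antiproliferative activity, read by CCK-8 assay, with a stated time of 6 days; on this read-out lower numbers stand for stronger inhibition and higher numbers for weaker inhibition:
compound 1 `CCN(c1ccc(C#N)c(Cl)c1)c1cc(-n2cnc3ccccc32)ccc1C`: 3040 nM
compound 2 `CCN(c1ccc(C#N)c(Cl)c1)c1cc(-c2ccc(F)nc2)ccc1C`: 16500 nM
compound 3 `CCN(c1ccc(C#N)c(Cl)c1)c1cc(-c2c[nH]nc2C)ccc1C`: 5380 nM

Compound 3 stands level with compound 1, a 1.8-fold higher number from compound 1 to compound 3 (0.25 log units; within the scatter), and clear of compound 2, a 3.1-fold lower number from compound 2 to compound 3 (0.49 log units; beyond the scatter). Compound 4 `CCN(c1ccc(C#N)c(Cl)c1)c1cc(-c2cn[nH]c2)ccc1C` keeps the core of compound 3 and differs in one place: hydrogen in place of methyl on an aromatic carbon. This is hydrogen in place of methyl on an aromatic carbon, turning 3-methyl-1H-pyrazol-4-yl into 1H-pyrazol-4-yl. Among the compounds with values here, no measured step removes such a methyl. The nearest evidence comes from exchanges of the whole substituent, and even the largest, a 5.4-fold higher number from compound 1 to compound 2 (0.73 log units; beyond the scatter), stayed modest. In this assay this smaller change is therefore expected to stay within the scatter, with no direction favoured. The expected result is a 1.1-fold higher number from compound 3 to compound 4 (0.05 log units; within the scatter). Compound 4 is estimated at 6000 nM, with an expected range of 2500 nM to 14000 nM.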

Compound 4, half-maximal inhibitory concentration: > 30000 nM
Compound 4 was reported as a limit (the forecaster's own chance of this, stated with the estimate: 5%); middle value at least 5.0-fold (0.69 log units) from the limit.
By their numbers in this assay, from the lowest: compounds 1 and 3 (each within the scatter of the next); then compound 2. At a limit, above all of these: compound 4.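

In this assay compound 4 gives only a limit, > 30000 nM. The single methyl on this carbon of the pyrazole therefore matters in a way the exchanges of whole substituents could not show: its loss gives an at least 5.5-fold higher number from compound 3 to compound 4 (0.74 log units; beyond the scatter). The other steps are an at least 9.8-fold higher number from compound 1 to compound 4 (0.99 log units; beyond the scatter) and an at least 1.8-fold higher number from compound 2 to compound 4 (0.25 log units; that floor lies within the scatter), and all three are floors set by the limit: the limit of > 30000 nM in this assay, at which 1 of the 4 values shown sits.

The compounds shown leave open whether an ethyl, a trifluoromethyl or an amine on that carbon would stay level with compound 3 or go the way of compound 4.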